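The source may report more compounds than this note shows. Statements on the series, on what has been measured and on what is new or still open speak of the compounds shown alone.

In a physicochemical assay, read by spectrophotometry, with a stated time of 30 min (on this read-out higher numbers stand for weaker inhibition and lower numbers for stronger inhibition), compound 1 `COc1ccc(C(CC(=O)c2c(O)c3ccccc3oc2=O)c2c[nH]c3ccccc23)c(OC)c1` gives 13.2 ug/mL and compound 2 `O=C(CC(c1ccc(O)c(O)c1)c1c[nH]c2ccccc12)c1c(O)c2ccccc2oc1=O` gives 71.1 ug/mL, so compound 2 stands at the higher number of the two, the weaker inhibition. Compound 3 `N#Cc1ccc(C(CC(=O)c2c(O)c3ccccc3oc2=O)c2c[nH]c3ccccc23)cc1` differs from compound 2 as follows: 4-cyanophenyl in place of 3,4-dihydroxyphenyl on a saturated chain carbon bound to an aromatic carbon and a saturated chain carbon. The swap sits on a saturated chain carbon bound to an aromatic carbon and a saturated chain carbon. For the measured compounds named here, one measured step bears on it, at that same place: a 5.4-fold higher number from compound 1 to compound 2 (0.73 log units; beyond the scatter). Going by the values given here, compound 1 also lacks the 3,4-dihydroxyphenyl, but no compound with 4-cyanophenyl has been measured, and two values cannot separate the group leaving from the group entering. A step towards a lower number in this assay is therefore expected, smaller than the measured one. For compound 3 the estimated value is 30 ug/mL, with an expected range of 9 ug/mL to 100 ug/mL. This estimate amounts to an expected 2.4-fold lower number from compound 2 to compound 3 (0.37 log units; beyond the scatter).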

Compound 3, half-maximal inhibitory concentration: 13.7 ug/mL
Compound 3: middle estimate off by 2.2-fold (0.34 log units), on the high side, and the stated range covers the measured number.
By their numbers in this assay, from the lowest: compounds 1 and 3 (each within the scatter of the next); then compound 2.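

Notes on the saturated chain carbon bound to an aromatic carbon and a saturated chain carbon: in this assay, 4-cyanophenyl in place of 3,4-dihydroxyphenyl gives a 5.2-fold lower number from compound 2 to compound 3 (0.72 log units; beyond the scatter), so the number of compound 2 is not a general feature of the shared core. Against 2,4-dimethoxyphenyl, 4-cyanophenyl gives a 1.0-fold higher number from compound 1 to compound 3 (0.02 log units; within the scatter), so two differently substituted phenyl groups cannot be told apart here, and among these three compounds only the 3,4-dihydroxyphenyl group stands apart, as the weakest. No measured evidence accounts for this difference. As far as these compounds go, whether the two hydroxyl groups act together or one alone suffices remains open, and so does the reading for the other substituents. A plain phenyl and a 4-hydroxyphenyl at this place would test both points.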